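Swapping 4-Phenylphenyl for Pyridin-4-yl: Cytotoxicity Outlook

This account rests on a few compounds, and the source may have more. Where it says the series, first, only, none or still open, it means among the compounds named here.

Compound 1 `Cc1cc(C#N)cc(C)c1Oc1nc(Nc2ccc(C#N)cc2)ncc1-c1ccc(-c2ccccc2)cc1` gives > 253000 nM in an ADME assay on MT4 cells (Homo sapiens) for cytotoxicity, read by MTT assay, with a stated time of 5 days (a higher number here means that more compound is tolerated, a lower number that less compound is tolerated), and this is a limit of the assay rather than a number. Compound 2 `Cc1cc(C#N)cc(C)c1Oc1nc(Nc2ccc(C#N)cc2)ncc1-c1ccc(N)cc1` gives 310 nM in this assay.

Compound 1 therefore sits at the upper edge of what the two values show: its result is a limit, (the limit of > 253000 nM in this assay, at which 1 of the 2 values shown sits), so its true value is not pinned down. Among the measured compounds shown here, the single measured step, an at least 810-fold lower number from compound 1 to compound 2 (2.91 log units; beyond the scatter), is large and beyond the scatter, and it came from altering the 4-phenylphenyl group of compound 1. Compound 3 `Cc1cc(C#N)cc(C)c1Oc1nc(Nc2ccc(C#N)cc2)ncc1-c1ccncc1` is not yet measured. It differs from compound 1 by pyridin-4-yl in place of 4-phenylphenyl on an aromatic carbon. For the measured compounds named here, because the only step on record, an at least 810-fold lower number from compound 1 to compound 2 (2.91 log units; beyond the scatter), also changed the 4-phenylphenyl group and moved the number far downward, a downward step in this assay is expected for compound 3 as well, though the amount cannot be read from one example. The estimated step is an at least 8.4-fold lower number from compound 1 to compound 3 (0.92 log units; beyond the scatter). Compound 3 is expected to give about 30000 nM in this assay, within a range from 3000 nM to 253000 nM.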

Compound 3, half-maximal cytotoxic concentration: 28000 nM
Beside the measured number, compound 3's estimate is 1.1-fold (0.03 log units) above it; the range from low to high includes it.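

Moving from the 4-phenylphenyl group to pyridin-4-yl on this aromatic carbon gives, in this assay, an at least 9.0-fold lower number from compound 1 to compound 3 (0.95 log units; beyond the scatter), so this group with a single ring gives a measured number well inside the range of the assay. The other single-ring group shown behaves very differently: exchanging 4-aminophenyl for pyridin-4-yl at the same place gives a 90-fold higher number from compound 2 to compound 3 (1.96 log units; beyond the scatter), so the number of rings at this position does not alone set the result, and compound 3 lies between the other two compounds. The first of these steps has no fixed size because the result for compound 1 is a limit and not a number: the limit of > 253000 nM in this assay, at which 1 of the 3 values shown sits.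

The compounds shown leave open where a plain phenyl group, a pyridin-3-yl group or a 4-hydroxyphenyl group would fall relative to compound 2 and compound 3 at this carbon. They also cannot separate the part played by the ring nitrogen of pyridin-4-yl from the part played by the loss of the outer ring of 4-phenylphenyl.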